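From a Methyl to a Chlorine on the Benzyl Group

The source may hold more compounds than are shown below. What is called first, only, known or untested is meant among the compounds shown, and "the series" means these compounds.

Measured so far:
compound 1 `Cc1ccccc1Cn1cc(COc2ccc3c(=O)ccoc3c2)nn1`: > 100000 nM
compound 2 `C#CCOc1ccc2c(=O)ccoc2c1`: 58500 nM

In a functional assay on QGY7701 cells (Homo sapiens) for cytotoxicity, read by MTT assay, with a stated time of 48 h (on this read-out higher numbers stand for weaker inhibition and lower numbers for stronger inhibition), compound 1 reaches only a limit of the assay, so its value of > 100000 nM is a boundary rather than a number. Compound 1 thus stands at the limit of > 100000 nM in this assay, at which 1 of the 2 values shown sits. In this assay compound 2 gives 58500 nM, a weak but measurable result. Among the measured compounds shown here, compound 2 and compound 1 differ in many places, so no single step between them can be read.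

Compound 3 `O=c1ccoc2cc(OCc3cn(Cc4cccc(Cl)c4)nn3)ccc12` has not yet been measured. It differs from compound 1 in one place: 3-chlorophenyl in place of 2-methylphenyl on a saturated chain carbon bound to an aromatic nitrogen. For the measured compounds named here, no measured pair shows what this change does, and compound 1 sits at a limit, so only a small shift in this assay is expected, no larger than the scatter. This expectation amounts to a step of a number no higher from compound 1 to compound 3 (the limit leaves the size open). Compound 3 is estimated at 100000 nM, within a range from 30000 nM to 300000 nM.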

Compound 3, half-maximal inhibitory concentration: 28400 nM
For compound 3 the middle estimate is 3.5-fold (0.55 log units) above the measured one, and the stated range ends above it.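

In this assay, putting 3-chlorophenyl in place of 2-methylphenyl on a saturated chain carbon bound to an aromatic nitrogen brings an at least 3.5-fold lower number from compound 1 to compound 3 (0.54 log units; beyond the scatter). Among the compounds shown here, this is the first readable step at this place: the earlier compounds offered no single change to read, whereas here the group on the benzyl carbon alone moves the read-out, and compound 3 gives a true number, 28400 nM, though still a weak one. Compound 1 stands only at a limit, so the full size of this step stays unknown: the limit of > 100000 nM in this assay, at which 1 of the 3 values shown sits.

The change alters both the substituent and its place on the ring, so the compounds shown cannot tell which of the two matters. A 3-methylbenzyl or a 2-chlorobenzyl group would separate them, and an amine on the same ring remains an open case.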